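This account rests on a few compounds, and the source may have more. Where it says the series, first, only, none or still open, it means among the compounds named here.

Compound 1 `COc1ccc(F)cc1Nc1cc(NC(=O)Nc2c(Cl)cccc2Cl)ncn1` in a functional assay on PC-9 cells (Homo sapiens) for inhibition, read by MTT assay, with a stated time of 48 h, tested at 10 uM (on this read-out higher numbers stand for more inhibition at the one concentration tested (going by the name of the read-out) and lower numbers for less inhibition), gives 85.5%. Compound 2 `COc1cc(Br)ccc1Nc1cc(NC(=O)Nc2c(Cl)cccc2Cl)ncn1` in this assay gives 90.5%; the step of a number 5 percentage points higher from compound 1 to compound 2 (within the scatter) places compound 2 highest of the two numbers, though its gap to compound 1 lies within the scatter. Compound 3 `COc1ccc(Nc2cc(NC(=O)Nc3c(Cl)cccc3Cl)ncn2)cc1C` is next; it differs from compound 2 by 4-methoxy-3-methylphenyl in place of 4-bromo-2-methoxyphenyl on a nitrogen on an aromatic ring. Within the data shown here, the only step that bears on it is the swap of the same aryl group in a number 5 percentage points higher from compound 1 to compound 2 (within the scatter), which stayed within the scatter, so no step beyond the scatter is expected in this assay; a number 5.5 percentage points lower from compound 2 to compound 3 (within the scatter) is the estimated change. Compound 3 is therefore expected at 85%, between 70% and 95%.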

Compound 3, a percentage reported as inhibition, at one concentration (the size of the read-out at that concentration, not a potency): 80.1%
Estimate against measurement, compound 3: 4.9 percentage points above, and the stated range covers the measured number.
By their numbers in this assay, from the lowest: compounds 3, 1 and 2 (each within the scatter of the next, the first and the last beyond it).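

In this assay the aryl group on a nitrogen on an aromatic ring now gives a step beyond the scatter: 4-methoxy-3-methylphenyl in place of 4-bromo-2-methoxyphenyl gives a number 10.4 percentage points lower from compound 2 to compound 3 (beyond the scatter). Among these compounds, the same group in place of 5-fluoro-2-methoxyphenyl gives a number 5.4 percentage points lower from compound 1 to compound 3 (within the scatter), so the swap registers beyond the scatter against only one of the two groups. No measurement at hand accounts for this difference. As far as these compounds go, the swap from compound 2 to compound 3 alters the bromine, the methyl and the place of the methoxy together, and which of these carries the step stays open. Also open, from the compounds shown here alone, is how an amine such as morpholine on this aryl group would read.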